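The compounds below may be only part of what the source reports. "The series", "measured", "known", "first", "only" and "open" are said of these compounds alone.

Measured compounds in a functional assay (plasma) for inhibition, with Homo sapiens as the target; a higher number here means a weaker inhibitor, a lower number a stronger inhibitor:
- compound 1 `CN(CCC1CCNCC1)C(=O)c1ccc2c(c1)CC(CC(=O)O)C(=O)N(C1CCCCC1)C2` gives 49 nM
- compound 2 `CC(C)N1Cc2ccc(C(=O)N(C)CCC3CCNCC3)cc2CC(CC(=O)O)C1=O` gives 37 nM
- compound 3 `CN(CCC1CCNCC1)C(=O)c1ccc2c(c1)CC(CC(=O)O)C(=O)N(CCC1CCCCC1)C2` gives 27 nM

Compound 2 sits between its two neighbours: a 1.3-fold lower number from compound 1 to compound 2 (0.12 log units; within the scatter), and a 1.4-fold lower number from compound 2 to compound 3 (0.14 log units; within the scatter). Both steps are within the scatter, so the three compounds cannot be separated on these numbers.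

Compound 4 `CN(CCC1CCNCC1)C(=O)c1ccc2c(c1)CC(CC(=O)O)C(=O)N(C)C2` differs from compound 2 by methyl in place of isopropyl on an amide-type nitrogen in a ring. Among the compounds with values here, the steps that bear on this change are all three measured ones, since each exchanges the group on the same ring nitrogen: a 1.3-fold lower number from compound 1 to compound 2 (0.12 log units; within the scatter), a 1.4-fold lower number from compound 2 to compound 3 (0.14 log units; within the scatter) and a 1.8-fold lower number from compound 1 to compound 3 (0.26 log units; within the scatter). None of them moves the number beyond the scatter, whether the group is isopropyl, cyclohexyl or 2-cyclohexylethyl. Methyl is smaller than any group measured so far, so the step into compound 4 goes past the range covered; still, with no measured step here beyond the scatter, no step beyond the scatter is expected in this assay, the expected step being a 1.2-fold higher number from compound 2 to compound 4 (0.09 log units; within the scatter). For compound 4 the estimate is 45 nM, with a range from 20 nM to 110 nM.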

Compound 4, half-maximal inhibitory concentration: 33 nM
For compound 4 the middle estimate is 1.4-fold (0.13 log units) above the measured one; the measured number falls inside the stated range.
By their numbers in this assay, from the lowest: compounds 3, 4, 2 and 1 (each within the scatter of the next).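

In this assay, within the data shown here, methyl on the amide-type nitrogen in the ring takes the series to a smaller group than any of the earlier compounds, and every new step stays within the scatter (a 1.1-fold lower number from compound 2 to compound 4 (0.05 log units; within the scatter); a 1.5-fold lower number from compound 1 to compound 4 (0.17 log units; within the scatter); a 1.2-fold higher number from compound 3 to compound 4 (0.09 log units; within the scatter)). At this position, two ring bonds from the ring atom bearing the carboxymethyl group, methyl, isopropyl, cyclohexyl and 2-cyclohexylethyl cannot be separated on these numbers, so the group's size, from methyl upward, shows no measurable link to the number here. No other data bear on this result.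

Going by these compounds, it remains open whether a benzyl group, a chain ending in an amine or a chain ending in a carboxylic acid on this nitrogen would also stay within the scatter. The same question stands for a longer acid chain in place of the carboxymethyl group.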